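Removing One Methyl Group Twice on the Same Core

A few compounds are considered here, and "the series" means these few. Any claim that something is new, unique, unknown or untested is made for them only; others in the source may bear on it.

Measured so far:
compound 1 `COc1cc(O)c(C(=O)/C=C/c2ccc(F)cc2)c(OC)c1` gives 28%
compound 2 `COc1cccc(/C=C/C(=O)c2c(OC)cc(OC)cc2OC)c1` gives 0.6%
compound 3 `COc1cc(OC)c(C(=O)/C=C/c2ccc(F)cc2)c(OC)c1` gives 0.7%

All three were tested in a functional assay on HCT-116 cells (Homo sapiens), read by fluorescence and BrdU incorporation, with a stated time of 48 h, tested at 25 uM; on this read-out higher numbers stand for a weaker effect at the one concentration tested and lower numbers for a stronger effect. Compound 3 and compound 1 share one core and differ only by hydrogen in place of methyl on an oxygen on an aromatic ring. That single change produced the step of a number 27.3 percentage points higher from compound 3 to compound 1 (beyond the scatter). The two cores themselves differ by 3-methoxyphenyl in place of 4-fluorophenyl on a double-bonded chain carbon bound to a double-bonded chain carbon, and across that difference the step of a number 0.1 percentage points higher from compound 2 to compound 3 (within the scatter) was small. Going by the values given here, compound 4 `COc1cccc(/C=C/C(=O)c2c(O)cc(OC)cc2OC)c1` is not yet measured; it differs from compound 2 by hydrogen in place of methyl on an oxygen on an aromatic ring, the same change as the one made from compound 3 to compound 1, at the same kind of place. From compound 2 to compound 4 a step of about a number 24.4 percentage points higher from compound 2 to compound 4 (beyond the scatter) is expected in this assay, resting on the earlier step of a number 27.3 percentage points higher from compound 3 to compound 1 (beyond the scatter). Compound 4 is therefore estimated at 25%, with a plausible span from 5% to 50%.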

Compound 4, a percentage reported as activity, at one concentration (the size of the read-out at that concentration, not a potency): 37%
Compound 4: the middle estimate sits 12 percentage points below what was measured; low and high end bracket the measured number.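

In this assay, going from methoxy to hydroxy on the core of compound 2 gives a number 36.4 percentage points higher from compound 2 to compound 4 (beyond the scatter), so the effect at the one concentration tested becomes weaker. The same change has now been seen on two cores, and the two steps agree in direction and in size: the same change on two cores in this assay, a number 27.3 percentage points higher (beyond the scatter) from compound 3 to compound 1 and a number 36.4 percentage points higher (beyond the scatter) from compound 2 to compound 4, 9.1 percentage points apart, within the scatter of two such steps

This shows that the change carried over between these two cores, but two cores cannot show that it would hold on a third. Nor do these results show why the effect weakens, and a reading at one concentration is not a potency.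

The compounds shown leave open what other groups would do at this place. An ethyl in place of the methyl on the oxygen, or an amine in place of the methoxy, could keep the effect or lose it as hydroxy does.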